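Dropping the phenol and restoring a second bromine

The source may report more compounds than this note shows. Statements on the series, on what has been measured and on what is new or still open speak of the compounds shown alone.

Measured compounds:
- compound 1, `O=C(Nc1ccc(Sc2nc3ccccc3s2)cc1)c1cc(Br)cc(Br)c1O`: 4700 nM
- compound 2, `COc1ccc(Br)cc1C(=O)Nc1ccc(Sc2nc3ccccc3s2)cc1`: > 100000 nM
- compound 3, `O=C(Nc1ccc(Sc2nc3ccccc3s2)cc1)c1cc(Br)ccc1O`: > 100000 nM

In an assay for inhibition of HSP60/HSP10 (Homo sapiens), with a stated time of 60 min (on this read-out higher numbers stand for weaker inhibition and lower numbers for stronger inhibition), compound 1 gives 4700 nM. For compound 2 the assay reports only a limit, > 100000 nM. For compound 3 likewise only a limit is reported, > 100000 nM, so compound 3 stands among the weakest values shown, at the limit of > 100000 nM in this assay, at which 2 of the 3 values shown sit.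

Compound 4, `O=C(Nc1ccc(Sc2nc3ccccc3s2)cc1)c1cc(Br)cc(Br)c1`, is not yet measured. It differs from compound 3 as follows: 3,5-dibromophenyl in place of 5-bromo-2-hydroxyphenyl on a carbonyl carbon. Among the compounds with values here, two measured steps bear on this. The step of an at least 21-fold higher number from compound 1 to compound 3 (1.32 log units; beyond the scatter) shows that taking away a bromo weakened inhibition strongly; compound 4 puts that bromo back. Within the data shown here, the step of an at least 21-fold higher number from compound 1 to compound 2 (1.32 log units; beyond the scatter) shows that capping the hydroxyl while removing a bromo also weakened inhibition strongly; compound 4 removes the hydroxyl outright, and no measured step separates the effect of the hydroxyl from that of the bromo, since a step that the two limits leave unreadable from compound 2 to compound 3.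

With the bromo restored but the hydroxyl gone, compound 4 is expected to gain somewhat over compound 3, an at least 2.5-fold lower number from compound 3 to compound 4 (0.39 log units; beyond the scatter), yet to stay weak. The estimate for compound 4 is 40000 nM, within 5000 nM to 100000 nM.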

Compound 4, half-maximal inhibitory concentration: > 100000 nM
Compound 4 ended at the assay's limit; the forecaster's own chance of this, stated with the estimate: 45%; middle value at least 2.5-fold (0.39 log units) away from the limit.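

In this assay, the hydroxy group of compound 1 now proves to matter by itself: replacing it with hydrogen, and changing nothing else, gives an at least 21-fold higher number from compound 1 to compound 4 (1.32 log units; beyond the scatter). Earlier, the hydroxy group had changed only together with a bromo, in the step to compound 2, while an at least 21-fold higher number from compound 1 to compound 3 (1.32 log units; beyond the scatter) showed the cost of losing that bromo alone, so the two single changes can now be set side by side, and each one costs compound 1 its measurable inhibition. Compound 2, compound 3 and compound 4 all sit at one limit, so the steps among them cannot be read, and only compound 1, with both the hydroxy group and the two bromo groups, gives a number: the limit of > 100000 nM in this assay, at which 3 of the 4 values shown sit.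

From the compounds shown here alone, the true loss from each change remains unknown, and so does whether the hydroxy group and the second bromo add up or depend on each other. Also open, going by these compounds, is whether an amine or a carboxylic acid in place of the hydroxy group, or chloro in place of either bromo, would keep the inhibition of compound 1.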